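Cytotoxicity of a Butylamino Analogue: Expectation Before Measurement

This account rests on a few compounds, and the source may have more. Where it says the series, first, only, none or still open, it means among the compounds named here.

Compound 3 `CS(=O)(=O)CCNC(=O)c1c(Cn2c(=O)n(C3CC3)c3ccncc32)nc2cc(Cl)ccn12` was tested in an ADME assay on HEp-2 cells (Homo sapiens) for cytotoxicity, read by CCK-8 assay, with a stated time of 6 days; a higher number here means that more compound is tolerated, a lower number that less compound is tolerated. In this assay compound 3 gives only a limit, > 100000 nM. Two related compounds stand at the same limit: compound 1 `O=c1n(Cc2nc3ccc(F)cn3c2CCCCO)c2cnccc2n1C1CC1` and compound 2 `O=c1n(Cc2nc3ccc(Cl)cn3c2CCCCO)c2cnccc2n1C1CC1`. In this assay compound 1 gives a limit, > 100000 nM. In this assay compound 2 gives a limit, > 100000 nM. The step that the two limits leave unreadable from compound 1 to compound 2 therefore has no readable size because of the limit of > 100000 nM in this assay, at which 3 of the 3 values shown sit. Compound 4 `CCCCNc1c(Cn2c(=O)n(C3CC3)c3ccncc32)nc2cc(Cl)ccn12` differs from compound 3 in one place: butylamino in place of (2-(methylsulfonyl)ethyl)carbamoyl on an aromatic carbon. For the measured compounds named here, no measured step bears on this change beyond the observation that all three values reach the same limit, so no direction can be read from them. The expected step is a number no higher from compound 3 to compound 4 (the limit leaves the size open), which lies within the scatter, and compound 4 is expected to reach the limit of this assay again. Compound 4 is estimated at 100000 nM in this assay, between 30000 nM and 300000 nM.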

Compound 4, half-maximal cytotoxic concentration: > 100000 nM
Compound 4 was reported as a limit; the forecaster's own chance of this, stated with the estimate: 70%; the middle value lies on the limit itself.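

No new step can be read between compound 3 and compound 4, because both stop at a limit rather than a number: the limit of > 100000 nM in this assay, at which 4 of the 4 values shown sit. The compounds shown leave open how much of each is actually tolerated, and whether either change alters it at all.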